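The source may hold more compounds than are shown below. What is called first, only, known or untested is meant among the compounds shown, and "the series" means these compounds.

In a functional assay on RAW264.7 cells (Mus musculus) for inhibition, read by Griess assay, with stated times of 2 h and 24 h (a higher number here means a weaker inhibitor, a lower number a stronger inhibitor), compound 1 `COc1ccc([C@@H]2CC(=O)c3c(O)cc(OCc4cn(Cc5ccc(C(F)(F)F)cc5)nn4)cc3O2)cc1O` gives 17700 nM, compound 2 `COc1ccc([C@@H]2CC(=O)c3c(O)cc(OCc4cn(Cc5ccccc5F)nn4)cc3O2)cc1O` gives 7320 nM, and compound 3 `C=CCn1cc(COc2cc(O)c3c(c2)O[C@H](c2ccc(OC)c(O)c2)CC3=O)nn1` gives 13800 nM. Compound 3 therefore lies within the scatter of both other compounds, although those two are separated by a 2.4-fold lower number from compound 1 to compound 2 (0.38 log units; beyond the scatter). Compound 4 `CCCCn1cc(COc2cc(O)c3c(c2)O[C@H](c2ccc(OC)c(O)c2)CC3=O)nn1` makes one change to compound 3: propyl in place of vinyl on a saturated chain carbon bound to an aromatic nitrogen. Allyl becomes butyl. The closest evidence comes from changes at this same place: a 1.3-fold lower number from compound 1 to compound 3 (0.11 log units; within the scatter) and a 1.9-fold higher number from compound 2 to compound 3 (0.28 log units; within the scatter), both within the scatter. Neither tests a saturated chain directly, so no step beyond the scatter is expected, in either direction. The expected change is small, a 1.2-fold lower number from compound 3 to compound 4 (0.06 log units; within the scatter). For compound 4, the estimated value in this assay is 12000 nM, with an expected range of 6000 nM to 24000 nM.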

Compound 4, half-maximal inhibitory concentration: 13900 nM
The estimate for compound 4 lay 1.2-fold (0.06 log units) below the measured number; measured number inside the range.
By their numbers in this assay, from the lowest: compounds 2, 3, 4 and 1 (each within the scatter of the next, the first and the last beyond it).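

In this assay, swapping allyl for butyl, and so removing the double bond outside aromatic rings, shifts the number by no more than the scatter (a 1.0-fold higher number from compound 3 to compound 4 (0.00 log units; within the scatter)). Butyl also stays within the scatter of the two compounds carrying an aromatic ring at this place (a 1.9-fold higher number from compound 2 to compound 4 (0.28 log units; within the scatter); a 1.3-fold lower number from compound 1 to compound 4 (0.10 log units; within the scatter)), so this saturated chain separates from neither. No supporting measurement is available to explain this result. As far as these compounds go, whether an amine, a carboxylic acid or a longer chain on this saturated chain carbon would move the number beyond the scatter remains open.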